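This account rests on a few compounds, and the source may have more. Where it says the series, first, only, none or still open, it means among the compounds named here.

Measured so far in an ADME assay on NIH3T3 cells (Mus musculus) for cytotoxicity, read by MTT assay; a higher number here means a weaker inhibitor, a lower number a stronger inhibitor:
- compound 1, `N#Cc1c(-c2ccccc2Cl)c(C#N)c(=O)n(/N=C/c2cn(-c3ccccc3)nc2-c2ccccc2)c1N`: 84 ug/mL
- compound 2, `N#Cc1c(-c2cccc(Cl)c2)c(C#N)c(=O)n(/N=C/c2cn(-c3ccccc3)nc2-c2ccccc2)c1N`: 52 ug/mL

Compound 2 gives the lowest of the two numbers shown; the step of a 1.6-fold lower number from compound 1 to compound 2 (0.21 log units; within the scatter) lies within the scatter, so the two compounds are not distinguished on this assay. Compound 3, `N#Cc1c(-c2ccc(F)cc2)c(C#N)c(=O)n(/N=C/c2cn(-c3ccccc3)nc2-c2ccccc2)c1N`, is not yet measured. It differs from compound 2 in one place: 4-fluorophenyl in place of 3-chlorophenyl on an aromatic carbon. Within the data shown here, only one measured step bears on a halogen exchanged on this phenyl group, the step from compound 1 to compound 2, and that step stayed within the scatter. A further change of the halogen and its position on the same phenyl group is therefore expected to move the number little, with no direction beyond the scatter, and a value for compound 3 near that of compound 2 is expected, as a step of a 1.2-fold higher number from compound 2 to compound 3 (0.08 log units; within the scatter). Compound 3 is estimated to give 62 ug/mL, within a range from 30 ug/mL to 125 ug/mL.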

Compound 3, half-maximal inhibitory concentration: > 200 ug/mL
Compound 3: a limit, no number; the forecaster's own chance of this, stated with the estimate: 10%; middle value at least 3.2-fold (0.50 log units) away from the limit.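

The halogen on this phenyl group turns out to matter in this assay, which the two chlorophenyl compounds alone could not show, as their step stayed within the scatter. With 4-fluorophenyl on this aromatic carbon, the data show an at least 3.8-fold higher number from compound 2 to compound 3 (0.58 log units; beyond the scatter) and an at least 2.3-fold higher number from compound 1 to compound 3 (0.37 log units; beyond the scatter), both beyond the scatter, so this change separates compound 3 from both chlorophenyl compounds. The reading for compound 3 is a limit of the assay and not a number: the limit of > 200 ug/mL in this assay, at which 1 of the 3 values shown sits.

These steps change the halogen and its place on the phenyl group together, and the compounds shown do not separate the two. From the compounds shown here alone, a 4-chlorophenyl or 3-fluorophenyl group on this carbon would bear on that question, while the effect of a phenyl group carrying an amine or a carboxylic acid also remains open.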